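Extending an Amide Chain on Two Related Cores

This account rests on a few compounds, and the source may have more. Where it says the series, first, only, none or still open, it means among the compounds named here.

compound 1 `CCCCCCCCCCCCCCCCCC(=O)Nc1nnc(S[C@@H]2O[C@H](CO)[C@H](O)[C@H](O)[C@H]2O)s1`: 11200 nM
compound 2 `CCCCCCCCCCCC(=O)Nc1nnc(S[C@@H]2O[C@H](CO)[C@H](O)[C@H](O)[C@H]2O)s1`: 8700 nM
compound 3 `CCCCCCCCCC(=O)Nc1nnc(S[C@@H]2O[C@H](COC(C)=O)[C@H](OC(C)=O)[C@H](OC(C)=O)[C@H]2OC(C)=O)s1`: 44900 nM

In a functional assay on HeLa cells (Homo sapiens) for cytotoxicity, read by MTT assay, with a stated time of 24 h (a lower number here means a stronger inhibitor, a higher number a weaker inhibitor), the three measured compounds fall into two groups. Compound 1 and compound 2 share one core; compound 3 carries another, and the difference between the core of compound 2 and the core of compound 3 is not broken down here. Compound 3 gives the highest number of the three, beyond the scatter from compound 1 and from compound 2. Between compound 2 and compound 1 the change is hexyl in place of hydrogen on a saturated chain carbon, ten or more bonds along the chain from a carbonyl carbon, and it made a 1.3-fold higher number from compound 2 to compound 1 (0.11 log units; within the scatter). Compound 4 `CCCCCCCCCCCCCCCC(=O)Nc1nnc(S[C@@H]2O[C@H](COC(C)=O)[C@H](OC(C)=O)[C@H](OC(C)=O)[C@H]2OC(C)=O)s1` is not yet measured; from compound 3 it differs by hexyl in place of hydrogen on a saturated chain carbon, nine bonds along the chain from a carbonyl carbon. This is the same kind of change, though not the same: the two hexyl groups sit at different distances along the chain from a carbonyl carbon, as the two descriptions of the changes show. Since the earlier step gave a 1.3-fold higher number from compound 2 to compound 1 (0.11 log units; within the scatter), compound 4 is expected to show a 1.2-fold higher number from compound 3 to compound 4 (0.06 log units; within the scatter). Compound 4 is estimated at 52000 nM, probably between 24000 nM and 115000 nM.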

Compound 4, half-maximal inhibitory concentration: 58300 nM
Estimate against measurement, compound 4: 1.1-fold (0.05 log units) below, and the stated range covers the measured number.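

In this assay, hexyl in place of hydrogen on the core of compound 3 gave a 1.3-fold higher number from compound 3 to compound 4 (0.11 log units; within the scatter). Set beside the earlier step, the change carries from one core to the other with no difference that can be told apart: the same change on two cores in this assay, a 1.3-fold higher number (0.11 log units; within the scatter) from compound 2 to compound 1 and a 1.3-fold higher number (0.11 log units; within the scatter) from compound 3 to compound 4, 1.0-fold (0.00 log units) apart, within the scatter of two such steps. This rests on a single pair on each core, with the hexyl at a different distance along the chain from a carbonyl carbon in each pair, so it does not show that the same would hold on other cores or for other changes.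

The compounds shown leave open whether a much shorter chain would give a similar step on either core. They also leave open how a chain ending in an amine or a carboxylic acid would behave.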